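Swapping the halogenated phenyl on a urea-linked quinoline series

The source may report more compounds than this note shows. Statements on the series, on what has been measured and on what is new or still open speak of the compounds shown alone.

Three compounds share one core and are compared in a functional assay on CCRF-CEM cells (Homo sapiens) for inhibition, read by MTT assay, with a stated time of 72 h; on this read-out lower numbers stand for stronger inhibition and higher numbers for weaker inhibition. Compound 1 `COc1cc(NC(C)CCCNC(=O)NNC(=O)Nc2ccc(Cl)cc2)c2ncccc2c1` gives 108000 nM in this assay, compound 2 `COc1cc(NC(C)CCCNC(=O)NNC(=O)Nc2ccc(C(F)(F)F)cc2)c2ncccc2c1` gives 18000 nM, and compound 3 `COc1cc(NC(C)CCCNC(=O)NNC(=O)Nc2ccc(Br)cc2)c2ncccc2c1` gives 110000 nM. Compound 3 therefore shows the highest of the three numbers, though its value sits within the scatter of compound 1, while compound 2 stands apart from both, as the step of a 6.1-fold higher number from compound 2 to compound 3 (0.79 log units; beyond the scatter) shows. The measured step of a 1.0-fold higher number from compound 1 to compound 3 (0.01 log units; within the scatter) indicates that exchanging one halogen for another at the same place leaves the number essentially unchanged.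

Compound 4 `COc1cc(NC(C)CCCNC(=O)NNC(=O)Nc2cccc(Cl)c2)c2ncccc2c1` differs from compound 3 in a single way: 3-chlorophenyl in place of 4-bromophenyl on an amide-type nitrogen. The step from compound 1 to compound 3 bears on it, because a bromo-to-chloro exchange gave a 1.0-fold higher number from compound 1 to compound 3 (0.01 log units; within the scatter). For the measured compounds named here, no measured step includes a 3-chlorophenyl group, so the effect of that part of the change is unknown. The expectation is therefore a step near the scatter, a 1.1-fold lower number from compound 3 to compound 4 (0.04 log units; within the scatter), with no clear direction. On that basis compound 4 is estimated at 100000 nM in this assay, within a range from 35000 nM to 280000 nM.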

Compound 4, half-maximal inhibitory concentration: 81000 nM
Compound 4: middle estimate off by 1.2-fold (0.09 log units), on the high side; the measured number falls inside the stated range.
By their numbers in this assay, from the lowest: compound 2; then compounds 4, 1 and 3 (each within the scatter of the next).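

For the compounds shown here, compound 4 is the first to show what happens when the aryl group changes its substitution pattern rather than its substituent: with 3-chlorophenyl in place of 4-chlorophenyl on the amide-type nitrogen, this assay gives a 1.3-fold lower number from compound 1 to compound 4 (0.12 log units; within the scatter), so this change stays inside the normal noise of the measurement. The comparison with the bromo analogue reads the same way, with a 1.4-fold lower number from compound 3 to compound 4 (0.13 log units; within the scatter), whereas a 4.5-fold higher number from compound 2 to compound 4 (0.65 log units; beyond the scatter) is a real, though modest, separation, so among these four compounds only the 4-(trifluoromethyl)phenyl group of compound 2 stands apart from the others. No independent measurement is available to explain why the three halogen-bearing compounds cluster together or why compound 2 differs.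

The compounds shown leave open how this assay responds to a plain phenyl with no substituent, or to a phenyl carrying a methoxy, nitrile or carboxylic acid group. They also leave open whether trifluoromethyl would keep its separation from the halogens if it took the place of the chloro in 3-chlorophenyl.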